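Swapping chloro for trifluoromethyl on a weak cytotoxic series

This account rests on a few compounds, and the source may have more. Where it says the series, first, only, none or still open, it means among the compounds named here.

Of the compounds shown here, three of one shared core have been tested in a functional assay on HL-60 cells (Homo sapiens) for cytotoxicity, read by MTT assay, with a stated time of 4 days; on this read-out higher numbers stand for weaker inhibition and lower numbers for stronger inhibition. Compound 1 `C=C1C[C@]23C[C@@]1(O)CC[C@H]2c1ccc(OS(=O)(=O)c2ccc(C)cc2)c(C)c1[C@@H]3Cn1cc(-c2ccc(Cl)cc2)nn1` reached only the limit of the assay, with > 20000 nM, so no number is known for it. Compound 2 `C=C1C[C@]23C[C@@]1(O)CC[C@H]2c1ccc(O)c(C)c1[C@@H]3Cn1cc(-c2ccccc2)nn1` likewise sits at a limit, giving > 20000 nM. Only compound 3 `C=C1C[C@]23C[C@@]1(O)CC[C@H]2c1cc(Br)c(O)c(C)c1[C@@H]3Cn1cc(-c2ccc(C(F)(F)F)cc2)nn1` yields an actual number, 7380 nM. Compound 1 therefore stands at the limit of > 20000 nM in this assay, at which 2 of the 3 values shown sit, and its true value can only be said to lie beyond that point. The unmeasured compound 4 `C=C1C[C@]23C[C@@]1(O)CC[C@H]2c1ccc(OS(=O)(=O)c2ccc(C)cc2)c(C)c1[C@@H]3Cn1cc(-c2ccc(C(F)(F)F)cc2)nn1` differs from compound 1 by one change: trifluoromethyl in place of chloro on an aromatic carbon. For the measured compounds named here, since no pair of measured compounds that differ in a single place exists here, no measured step can guide the size of this one; the only hint is that compound 3, which also carries the trifluoromethyl group, gave 7380 nM, though it differs in other places too. From compound 1 to compound 4 the step is expected to be an at least 1.1-fold lower number from compound 1 to compound 4 (0.04 log units; that floor lies within the scatter), with a real chance that the assay again reports only a limit. Compound 4 is expected to give about 18000 nM, within a range from 6000 nM to 60000 nM.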

Compound 4, half-maximal inhibitory concentration: > 20000 nM
Compound 4 gave a limit, no number (the forecaster's own chance of this, stated with the estimate: 60%); at least 1.1-fold (0.04 log units) between middle value and limit.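

Compound 1 and compound 4 both end at the same limit rather than at a number, so no step from chloro to trifluoromethyl can be read between them: the limit of > 20000 nM in this assay, at which 3 of the 4 values shown sit.

The compounds shown leave open whether this swap changes the cytotoxic effect at all, since the true values of compound 1 and compound 4 remain unknown.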